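Thiazolidine propiolamides: aryl versus alkyl at the ring carbon

This account rests on a few compounds, and the source may have more. Where it says the series, first, only, none or still open, it means among the compounds named here.

Within the data shown here, compound 2 `C#CC(=O)N1C(C(CC)CCCC)SC[C@@H]1C(=O)OCC` gives 1600 nM in a functional assay on MV cells (Homo sapiens) for inhibition, read by sulforhodamine B assay (a lower number here means a stronger inhibitor, a higher number a weaker inhibitor), the lowest of the two numbers so far; the nearest is compound 1 `C#CC(=O)N1C(c2ccccc2F)SC[C@@H]1C(=O)OCC`, which gives 1700 nM, a gap within the scatter. Among the measured compounds shown here, the only measured step, a 1.1-fold lower number from compound 1 to compound 2 (0.03 log units; within the scatter), shows that swapping aryl for alkyl at this ring carbon left the number essentially unchanged. Compound 3 `C#CC(=O)N1C(c2cccc(F)c2)SC[C@@H]1C(=O)OCC` carries the change (3-fluorophenyl in place of 1-ethylpentyl on a saturated ring carbon). For the measured compounds named here, since the one comparable exchange stayed within the scatter, no step beyond the scatter is expected in this assay here either, a 1.1-fold higher number from compound 2 to compound 3 (0.03 log units; within the scatter). Compound 3 is therefore estimated at 1700 nM, range 800 nM to 3600 nM.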

Compound 3, half-maximal inhibitory concentration: 1700 nM
For compound 3 middle estimate and measured number coincide at the digits printed; measured number inside the range.
By their numbers in this assay, from the lowest: compounds 2, 1 and 3 (each within the scatter of the next).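

In this assay 3-fluorophenyl in place of 1-ethylpentyl gives a 1.1-fold higher number from compound 2 to compound 3 (0.03 log units; within the scatter) and so confirms, with a second aryl group, that aryl and alkyl are not separated at this ring carbon. 3-fluorophenyl in place of 2-fluorophenyl gives no change at the digits printed from compound 1 to compound 3 (within the scatter) and adds the first sign that the fluorine's place on the phenyl ring does not separate these compounds. No evidence is available on the reason for this flat result. Still open, as far as these compounds go, is whether an amine, a carboxylic acid or a longer chain at this ring carbon would give a step beyond the scatter.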